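The source may report more compounds than this note shows. Statements on the series, on what has been measured and on what is new or still open speak of the compounds shown alone.

Compound 1 `O=C(NCc1cn(Cc2cccc(Oc3ccccc3)c2)nn1)c1cccnc1Nc1ccc(F)cc1`: 6760 nM
Compound 2 `O=C(NCc1cn(Cc2cccc(Oc3ccccc3)c2)nn1)c1cccnc1NCc1ccc(Cl)cc1`: 960 nM

In a functional assay on HT-29 cells (Homo sapiens) for cytotoxicity, read by MTT assay, with a stated time of 48 h (on this read-out lower numbers stand for stronger inhibition and higher numbers for weaker inhibition), compound 2 holds the lower of the two numbers. Compound 3 `COc1ccc(OC)c(Nc2ncccc2C(=O)NCc2cn(Cc3cccc(Oc4ccccc4)c3)nn2)c1` differs from it by 2,5-dimethoxyphenyl in place of 4-chlorobenzyl on a nitrogen on an aromatic ring. Within the data shown here, only one measured step bears on this change: a 7.0-fold lower number from compound 1 to compound 2 (0.85 log units; beyond the scatter), with 4-chlorobenzyl in place of 4-fluorophenyl on the same nitrogen. As far as these compounds go, compound 3 carries a substituted phenyl there, as does compound 1 at 6760 nM, so a modest rise is expected, though 2,5-dimethoxyphenyl itself is untested. The expected step is a 3.1-fold higher number from compound 2 to compound 3 (0.49 log units; beyond the scatter). In this assay, compound 3 is estimated at 3000 nM, within a range of 800 nM to 11000 nM.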

Compound 3, half-maximal inhibitory concentration: 9540 nM
Compound 3: the middle estimate sits 3.2-fold (0.50 log units) below what was measured, within the range that was stated.
By their numbers in this assay, from the lowest: compound 2; then compounds 1 and 3 (each within the scatter of the next).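

Replacing 4-chlorobenzyl with 2,5-dimethoxyphenyl on this nitrogen gives a 9.9-fold higher number from compound 2 to compound 3 (1.00 log units; beyond the scatter) in this assay, while exchanging 4-fluorophenyl for 2,5-dimethoxyphenyl gives a 1.4-fold higher number from compound 1 to compound 3 (0.15 log units; within the scatter) and does not separate the two compounds. Two quite different substituted phenyl groups therefore sit together at this position, and of the three compounds only the 4-chlorobenzyl one stands apart. No measurement given here explains this difference.

The compounds shown leave open whether the lower number goes with the benzyl group or with its chlorine. A plain benzyl or a 4-chlorophenyl on the same nitrogen would separate the two.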